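A Single Fluoro on Compound 3: What to Expect

The compounds below may be only part of what the source reports. "The series", "measured", "known", "first", "only" and "open" are said of these compounds alone.

In a physicochemical assay for solubility, measured as kinetic solubility, with a stated time of 1 h, at pH 7.4 (on this read-out higher numbers stand for higher solubility and lower numbers for lower solubility), compound 2 `CC(=O)Nc1nc(-c2ccc(Cl)c(F)c2)cs1` gives 5000 nM and compound 3 `O=C(NC1=NN(c2ccc(Cl)c(Cl)c2)CC1)c1ccncc1` gives 9000 nM, two numbers within the usual scatter of each other. Compound 1 `CC(=O)Nc1nc(-c2ccc(Cl)c(Cl)c2)cs1` gives < 1000 nM, which is a limit of the assay and not a number.

Compound 4 `O=C(NC1=NN(c2ccc(Cl)c(Cl)c2)CC1)c1ccncc1F` differs from compound 3 in one place: fluoro in place of hydrogen on an aromatic carbon. Pyridin-4-yl becomes 3-fluoropyridin-4-yl, with fluoro in place of hydrogen on an aromatic carbon, two atoms from the ring nitrogen.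

Among the compounds with values here, the only measured step is an at least 5.0-fold higher number from compound 1 to compound 2 (0.69 log units; beyond the scatter). That step put fluoro in place of chloro, whereas here fluoro replaces hydrogen on a different ring, so it is a weak guide to compound 4. With no closer comparison available, a large move in either direction is not expected.

The step expected in this assay is a 1.4-fold lower number from compound 3 to compound 4 (0.14 log units; within the scatter), which would stay within the scatter. For compound 4 the estimated value is 6500 nM, with an expected range of 2000 nM to 18000 nM.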

Compound 4, solubility: 36000 nM
The estimate for compound 4 lay 5.5-fold (0.74 log units) below the measured number, outside the stated range (above it).
By their numbers in this assay, from the lowest: compounds 2 and 3 (each within the scatter of the next); then compound 4. At a limit, below all of these: compound 1.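

In this assay, turning pyridin-4-yl into 3-fluoropyridin-4-yl brings a 4.0-fold higher number from compound 3 to compound 4 (0.60 log units; beyond the scatter), a step beyond the scatter. This shows that a single fluoro in place of hydrogen, at this place ortho to a large group and two atoms from the ring nitrogen, can shift the read-out on this ring, whereas the earlier step, fluoro in place of chloro, lay on a different ring of a different core. That earlier step also starts from a limit, so only its smallest possible size is known, while this one has a measured number at both ends.

As far as these compounds go, whether an amine or a methyl group at this same place would shift the number in the same way stays open, as does the effect of fluoro elsewhere on this ring. No measurement shown here bears on why the number rose.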